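This account rests on a few compounds, and the source may have more. Where it says the series, first, only, none or still open, it means among the compounds named here.

Compound 3 `CCCCCOc1cccc(C(=O)Nc2cccc(C(=O)O)c2)c1` gives 2540 nM in an assay on isolated protein for agonist activity at Bile acid receptor (Homo sapiens), read by TR-FRET, with a stated time of 3 h, in the absence of a further agent; on this read-out higher numbers stand for an effect only at larger amounts of compound and lower numbers for an effect already at smaller amounts; among the three measured it stands second highest, with compound 2 `CCCCOc1cccc(C(=O)Nc2cccc(C(=O)O)c2)c1` at 3150 nM nearest and compound 1 `COc1cccc(C(=O)Nc2cccc(C(=O)O)c2)c1` at 1040 nM furthest. Compound 4 `O=C(O)c1cccc(NC(=O)c2cccc(OCC3CC3)c2)c1` differs from compound 3 by cyclopropyl in place of butyl on a saturated chain carbon bound to an oxygen on an aromatic ring. Steps bearing on it: a 3.0-fold higher number from compound 1 to compound 2 (0.48 log units; beyond the scatter) and a 2.4-fold higher number from compound 1 to compound 3 (0.39 log units; beyond the scatter) both moved the number upward on going from the shortest chain to longer ones, whereas a 1.2-fold lower number from compound 2 to compound 3 (0.09 log units; within the scatter) showed that one more chain carbon between those two changed nothing beyond the scatter. Cyclopropyl keeps the chain shorter than butyl but longer than hydrogen, so in this assay a step of about a 1.2-fold lower number from compound 3 to compound 4 (0.06 log units; within the scatter) is expected, if any beyond the scatter. Compound 4 is estimated at 2200 nM, range 900 nM to 5000 nM.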

Compound 4, half-maximal effective concentration: 1260 nM
Compound 4: middle estimate off by 1.7-fold (0.24 log units), on the high side; the measured number falls inside the stated range.
By their numbers in this assay, from the lowest: compounds 1, 4, 3 and 2 (each within the scatter of the next, the first and the last beyond it).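

In this assay, cyclopropyl on a saturated chain carbon bound to an oxygen on an aromatic ring does not carry over the rise seen with propyl and butyl, with a 1.2-fold higher number from compound 1 to compound 4 (0.08 log units; within the scatter) against hydrogen. Against the open chains the result is split, with a 2.5-fold lower number from compound 2 to compound 4 (0.40 log units; beyond the scatter) against propyl but a 2.0-fold lower number from compound 3 to compound 4 (0.30 log units; within the scatter) against butyl, so added carbons alone do not set the number here. No evidence on hand accounts for this.

Still open, from the compounds shown here alone, is whether the three-membered ring itself matters or only the shape of the chain. Cyclobutyl, isopropyl or an amine at this place would test that.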